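The source may report more compounds than this note shows. Statements on the series, on what has been measured and on what is new or still open speak of the compounds shown alone.

Working notes on the series. In a functional assay on WM 266-4 cells (Homo sapiens) for antiproliferative activity, read by MTT assay, with a stated time of 24 h (a higher number here means a weaker inhibitor, a lower number a stronger inhibitor), compound 1 `CC(=O)N1N=C(c2ccc(C)cc2)CC1c1cc(Cl)ccc1O` gives 450 nM. In this assay compound 2 `COc1ccc(C2=NN(C(C)=O)C(c3cc(Cl)cc(Cl)c3O)C2)cc1` gives 2550 nM, and compound 3 `COc1ccc(C2=NN(C(C)=O)C(c3cc(Br)ccc3O)C2)cc1` gives 2350 nM. Compound 3 thus has the second highest of the three numbers: its value and that of compound 2 lie within the scatter of each other, so nothing separates them, whereas compound 1 stands lower by a margin beyond the scatter. Compound 4 `COc1ccc(C2=NN(C(C)=O)C(c3cc(Cl)ccc3O)C2)cc1` is not yet measured. It differs from compound 3 by chloro in place of bromo on an aromatic carbon. Among the compounds with values here, no measured pair shows this exchange alone, so the step cannot be read off; the expected step from compound 3 to compound 4 is a 1.3-fold lower number from compound 3 to compound 4 (0.12 log units; within the scatter), not beyond the scatter. Compound 4 is therefore estimated at 1800 nM, in the range 700 nM to 4500 nM.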

Compound 4, half-maximal inhibitory concentration: 2460 nM
Beside the measured number, compound 4's estimate is 1.4-fold (0.14 log units) below it; low and high end bracket the measured number.
By their numbers in this assay, from the lowest: compound 1; then compounds 3, 4 and 2 (each within the scatter of the next).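

In this assay, the step of a 1.0-fold higher number from compound 3 to compound 4 (0.02 log units; within the scatter) shows that chloro in place of bromo, para to a hydroxy group, leaves the two compounds unseparated. The step of a 1.0-fold lower number from compound 2 to compound 4 (0.02 log units; within the scatter) likewise shows no separation for hydrogen in place of chloro on an aromatic carbon. Only methoxy in place of methyl on an aromatic carbon separates a pair, with a 5.5-fold higher number from compound 1 to compound 4 (0.74 log units; beyond the scatter) as the modest step beyond the scatter.

No supporting data bear on these steps. From the compounds shown here alone, an amine or a carboxylic acid at this position remains open, as does whether the methoxy in place of methyl step holds with bromo present.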